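Naphthalen-2-yl to 1H-indol-2-yl on the amide carbonyl

A few compounds are considered here, and "the series" means these few. Any claim that something is new, unique, unknown or untested is made for them only; others in the source may bear on it.

Compound 1 `CN1[C@@H]2c3[nH]c4ccccc4c3C[C@H]1[C@H](C#N)N1[C@@H](CN3C(=O)c4ccccc4C3=O)c3[nH]c4ccccc4c3C[C@@H]21` gives 80 nM in a functional assay on HT-29 cells (Homo sapiens) for cytotoxicity, read by MTT assay, with a stated time of 72 h; a higher number here means a weaker inhibitor, a lower number a stronger inhibitor.
Compound 2 `CCc1ccc(C(=O)NC[C@H]2c3[nH]c4ccccc4c3C[C@H]3[C@H]4c5[nH]c6ccccc6c5C[C@@H]([C@H](C#N)N23)N4C)cc1` gives 3560 nM in this assay.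
Compound 3 `CN1[C@@H]2c3[nH]c4ccccc4c3C[C@H]1[C@H](C#N)N1[C@@H](CNC(=O)c3ccc4ccccc4c3)c3[nH]c4ccccc4c3C[C@@H]21` gives 4940 nM in this assay.

Compound 3 carries the highest number of the three, although compound 2 sits within the scatter of it; compound 1 lies far lower. Compound 4 `CN1[C@@H]2c3[nH]c4ccccc4c3C[C@H]1[C@H](C#N)N1[C@@H](CNC(=O)c3cc4ccccc4[nH]3)c3[nH]c4ccccc4c3C[C@@H]21` differs from compound 3 by 1H-indol-2-yl in place of naphthalen-2-yl on a carbonyl carbon. The step that bears on this is a 1.4-fold higher number from compound 2 to compound 3 (0.14 log units; within the scatter), which exchanged one aromatic group for another on the same carbonyl carbon and stayed within the scatter. The large step of a 45-fold higher number from compound 1 to compound 2 (1.65 log units; beyond the scatter) concerns a different change and gives no guidance here. A step of no consequence beyond the scatter is therefore expected, a 1.2-fold lower number from compound 3 to compound 4 (0.09 log units; within the scatter). Compound 4 is estimated at 4000 nM, with a range from 1500 nM to 12000 nM.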

Compound 4, half-maximal inhibitory concentration: 1220 nM
Compound 4: middle estimate off by 3.3-fold (0.52 log units), on the high side; measured number outside the range, below it.
By their numbers in this assay, from the lowest: compound 1; then compound 4; then compounds 2 and 3 (each within the scatter of the next).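

On the carbonyl carbon, the choice of aromatic group does change the number: a 4.0-fold lower number from compound 3 to compound 4 (0.61 log units; beyond the scatter) and a 2.9-fold lower number from compound 2 to compound 4 (0.47 log units; beyond the scatter) both lie beyond the scatter, so 1H-indol-2-yl separates from naphthalen-2-yl and 4-ethylphenyl, which remain within the scatter of each other. Still, a 15-fold higher number from compound 1 to compound 4 (1.18 log units; beyond the scatter) leaves compound 4 well short of the group carried by compound 1. Nothing available accounts for the gain with 1H-indol-2-yl.

Whether the ring nitrogen of 1H-indol-2-yl is what counts remains open, since benzofuran-2-yl, with oxygen in that ring, is not among these compounds. From the compounds shown here alone, how a saturated chain or an amine on this carbonyl carbon would compare is also open.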